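Fluoro in Place of Hydrogen, Repeated on a Second Core

The source may report more compounds than this note shows. Statements on the series, on what has been measured and on what is new or still open speak of the compounds shown alone.

Compound 1, `COc1cccc(Cc2cc(-c3ccccc3)nn(CC(=O)Nc3ccc(F)cc3)c2=O)c1`: a limit, > 50000 nM
Compound 2, `COc1cccc(Cc2cc(-c3ccc(F)cc3)nn(CC(=O)Nc3ccc(F)cc3)c2=O)c1`: a limit, > 50000 nM
Compound 3, `Cc1cc(Cc2ccccc2)c(=O)n(CC(=O)Nc2ccc(Br)cc2)n1`: a limit, > 50000 nM

In a functional assay on HL-60 cells (Homo sapiens), read by calcium flux (a lower number here means that less compound is needed, a higher number that more compound is needed for the effect), each of the three measured compounds reaches only the limit (the limit of > 50000 nM in this assay, at which 3 of the 3 values shown sit). Compound 2 differs from compound 1 by fluoro in place of hydrogen on an aromatic carbon, and the step that the two limits leave unreadable from compound 1 to compound 2 cannot be read, since both ends are limits. Compound 4, `Cc1cc(Cc2cccc(F)c2)c(=O)n(CC(=O)Nc2ccc(Br)cc2)n1`, is not yet measured; it differs from compound 3 by fluoro in place of hydrogen on an aromatic carbon. This is the same kind of change as from compound 1 to compound 2, but the place differs: para to a large group in the one, meta to a large group in the other. The difference between the two cores is not broken down here. Compound 3 itself is known only as a limit, so compound 4 is expected to show the step that the limit leaves unreadable from compound 3 to compound 4, most likely remaining at the limit as well. Compound 4 is therefore estimated at 60000 nM, between 15000 nM and 250000 nM.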

Compound 4, half-maximal effective concentration: > 50000 nM
Compound 4 was reported as a limit (the forecaster's own chance of this, stated with the estimate: 85%); the middle value lies beyond the limit too.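

In this assay, for the compounds shown here, compound 4 gives > 50000 nM, which is a limit, and compound 3 is also a limit, so no step from compound 3 to compound 4 can be read. The compounds shown leave open whether fluoro in place of hydrogen changes the response on either core at all: the limit of > 50000 nM in this assay, at which 4 of the 4 values shown sit.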